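The compounds below may be only part of what the source reports. "The series", "measured", "known", "first", "only" and "open" are said of these compounds alone.

Compound 1 `C/C(=N\CCO)c1c(O)c2ccccc2[nH]c1=O`: in an assay on isolated protein for inhibition of myosin-2 (Bos taurus), read by spectrophotometry, with a stated time of 24 min (on this read-out higher numbers stand for weaker inhibition and lower numbers for stronger inhibition), compound 1 gives >= 100000 nM, which is a limit of the assay and not a number.
Compound 2 `CCCC/N=C(\C)c1c(O)c2ccccc2[nH]c1=O`: in this assay compound 2 gives >= 100000 nM, likewise a limit.
Among the measured compounds shown here, compound 3 `CCCCC/N=C(\C)c1c(O)c2ccccc2oc1=O`: in this assay compound 3 gives 6700 nM, the only number among the three.

Compound 2 and compound 1 differ by hydroxy in place of ethyl on a saturated chain carbon, two bonds along the chain from a double-bonded nitrogen. The step that the two limits leave unreadable from compound 2 to compound 1 cannot be sized because the limit of >= 100000 nM in this assay, at which 2 of the 3 values shown sit, is where both values sit. How the core of compound 3 differs from that of compound 2 is not broken down here.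

Compound 4 `C/C(=N\CCCO)c1c(O)c2ccccc2oc1=O` differs from compound 3 by hydroxy in place of ethyl on a saturated chain carbon, three bonds along the chain from a double-bonded nitrogen. This is the same kind of change as that from compound 2 to compound 1, but the place differs: three bonds along the chain from the double-bonded nitrogen rather than two. The measured instance gives no readable size, so the expectation rests only on compound 3 giving 6700 nM and on the entering hydroxy group. Compound 4 is expected to give 25000 nM in this assay, somewhere between 7000 nM and 100000 nM. The expected step of a 3.7-fold higher number from compound 3 to compound 4 (0.57 log units; beyond the scatter) is a loss, with a fair chance that only a limit is reported.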

Compound 4, half-maximal inhibitory concentration: 37000 nM
Compound 4: the middle estimate sits 1.5-fold (0.17 log units) below what was measured, within the range that was stated.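

On the core of compound 3, the change of ethyl to hydroxy in this assay gives a 5.5-fold higher number from compound 3 to compound 4 (0.74 log units; beyond the scatter), a loss of inhibition that still leaves a readable number. The step from compound 2 to compound 1, on another core and two bonds rather than three along the chain from the double-bonded nitrogen, cannot be read: the limit of >= 100000 nM in this assay, at which 2 of the 4 values shown sit. The size of the change is therefore known on one core only, and nothing shown says whether it carries over to the other.

The compounds shown leave open whether the loss comes from the entering hydroxy or from the departing ethyl, a question that a plain propyl chain on the core of compound 3 would bear on. They also leave open how an amine or a carboxylic acid at the chain end would compare with the hydroxy of compound 4.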